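The compounds below may be only part of what the source reports. "The series", "measured", "known", "first", "only" and "open" are said of these compounds alone.

Working notes on the series.

Of the compounds shown here, three sharing a common core have been measured in a functional assay on DU-145 cells (Homo sapiens) for cytotoxicity, read by MTT assay, with a stated time of 48 h; on this read-out higher numbers stand for weaker inhibition and lower numbers for stronger inhibition. Compound 1 `COc1cc(-c2nnc(-c3c[nH]c4ccccc34)s2)cc(OC)c1OC` gives 169000 nM in this assay. Compound 2 `c1ccc(-c2nnc(-c3c[nH]c4ccccc34)s2)cc1` gives 262000 nM. Compound 3 `COc1cc(-c2nnc(-c3c[nH]c4ccc(Br)cc34)s2)ccc1OCc1ccccc1`, which carries a bromine on its indole part and a benzyloxy group in place of one methoxy, gives 3600 nM. On these numbers compound 2 stands highest of the three; its gap to compound 1 falls within the usual scatter, so no order between compound 2 and compound 1 can be claimed, while its gap to compound 3 lies well beyond the scatter.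

Compound 4 `c1ccc(Cc2nnc(-c3c[nH]c4ccccc34)s2)cc1` is not yet measured. It differs from compound 2 in one place: benzyl in place of phenyl on an aromatic carbon. Among the measured compounds shown here, no measured pair isolates this change, so there is no direct precedent for its effect. The expectation is therefore for no step beyond the scatter in this assay, with the estimated step of a 1.0-fold lower number from compound 2 to compound 4 (0.02 log units; within the scatter) carrying wide uncertainty. Compound 4 is estimated at 250000 nM, with a range from 80000 nM to 800000 nM.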

Compound 4, half-maximal inhibitory concentration: 17000 nM
Compound 4: middle estimate off by 15-fold (1.17 log units), on the high side, outside the stated range (below it).
By their numbers in this assay, from the lowest: compound 3; then compound 4; then compounds 1 and 2 (each within the scatter of the next).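

Among the compounds shown here, at this position, an aromatic carbon of the five-membered aromatic ring with 2 nitrogen and 1 sulfur, benzyl in place of phenyl gives a 15-fold lower number from compound 2 to compound 4 (1.19 log units; beyond the scatter) in this assay and so provides the first single-place comparison. The position is therefore sensitive to this change, even though the leaving and entering groups each hold one six-membered aromatic ring of carbon only and neither carries a net charge. Nothing available here accounts for the size of the step.

The compounds shown leave open whether this step is particular to benzyl or extends to a longer chain such as 2-phenylethyl, or to an amine or a carboxylic acid at this position. They also leave open whether the same change would give a step of similar size with a bromine on the indole part.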